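This account rests on a few compounds, and the source may have more. Where it says the series, first, only, none or still open, it means among the compounds named here.

In an ADME assay on Raji cells (Homo sapiens) for cytotoxicity, with a stated time of 72 h (on this read-out lower numbers stand for an effect already at smaller amounts and higher numbers for an effect only at larger amounts of compound), the measured compounds stand as follows.
Compound 1 `Cc1cc(NC(=O)Nc2ccc(N)cc2)c2ccccc2n1`: a limit of the assay, > 25000 nM.
Compound 2 `Cc1cc(NC(=O)Nc2cccc(Cl)c2)c2ccccc2n1`: 18000 nM.
Compound 3 `Cc1cc(NC(=O)Nc2ccc(F)cc2)c2ccccc2n1`: a limit of the assay, > 25000 nM.

Compound 3 thus has only a limit, and it sits at the limit of > 25000 nM in this assay, at which 2 of the 3 values shown sit. The step of an at least 1.3-fold higher number from compound 2 to compound 3 (0.14 log units; that floor lies within the scatter) is a floor within the scatter, and the step that the two limits leave unreadable from compound 1 to compound 3 cannot be read. Compound 4 `CSc1ccc(NC(=O)Nc2cc(C)nc3ccccc23)cc1` differs from compound 3 by methylsulfanyl in place of fluoro on an aromatic carbon. Among the measured compounds shown here, no measured step touches a methylsulfanyl group, so nothing in the data argues for a move beyond the scatter in this assay, and the value for compound 4 is expected to stay near the limit. Compound 4 is therefore estimated at 25000 nM, between 10000 nM and 60000 nM, an expected step of a number no higher from compound 3 to compound 4 (the limit leaves the size open).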

Compound 4, half-maximal effective concentration: > 25000 nM
Compound 4: no number, only a limit (the forecaster's own chance of this, stated with the estimate: 60%); the middle value lies on the limit itself.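

Compound 4 gives only a limit of the assay, > 25000 nM, so its steps from compound 1 and compound 3 cannot be read. The compounds shown leave open whether compound 1, compound 3 and compound 4 differ from one another at all: the limit of > 25000 nM in this assay, at which 3 of the 4 values shown sit.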